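This account rests on a few compounds, and the source may have more. Where it says the series, first, only, none or still open, it means among the compounds named here.

Compound 1 `CN1CCN(c2ccc(Nc3ncc4nc(Nc5ccccc5)n([C@@H]5CCNC5)c4n3)cc2)CC1` gives 65 nM in a functional assay on HCC827 cells (Homo sapiens) for antiproliferative activity, read by MTT assay, with a stated time of 72 h; on this read-out higher numbers stand for weaker inhibition and lower numbers for stronger inhibition. Compound 2 `CN1CCN(c2ccc(Nc3ncc4nc(Nc5ccccc5)n([C@H]5CCN(S(=O)(=O)C6CC6)C5)c4n3)cc2)CC1` carries 1-(cyclopropylsulfonyl)pyrrolidin-3-yl in place of pyrrolidin-3-yl on an aromatic nitrogen and in this assay compound 2 gives 1.6 nM, so that change produced a 41-fold lower number from compound 1 to compound 2 (1.61 log units; beyond the scatter). Compound 3 `CN1CCN(c2ccc(Nc3ncc4nc(Nc5ccc(F)cc5)n([C@@H]5CCNC5)c4n3)cc2)CC1` differs from compound 1 in its core by fluoro in place of hydrogen on an aromatic carbon, and in this assay compound 3 gives 300 nM, a step of a 4.6-fold higher number from compound 1 to compound 3 (0.66 log units; beyond the scatter). Compound 4 `CN1CCN(c2ccc(Nc3ncc4nc(Nc5ccc(F)cc5)n([C@H]5CCN(S(=O)(=O)C6CC6)C5)c4n3)cc2)CC1` has not yet been measured; it carries 1-(cyclopropylsulfonyl)pyrrolidin-3-yl in place of pyrrolidin-3-yl on an aromatic nitrogen. Among the compounds with values here, this is the same kind of change as the one made to reach compound 2, the place differing only in that the ring atom next to it bears a (4-fluorophenyl)amino group (8 heavy atoms) rather than an anilino group (7 heavy atoms). Because the earlier pair showed a 41-fold lower number from compound 1 to compound 2 (1.61 log units; beyond the scatter), a step of comparable size, a 38-fold lower number from compound 3 to compound 4 (1.57 log units; beyond the scatter), is expected here, resting on that single earlier pair alone. Compound 4 is therefore estimated to give 8 nM in this assay.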

Compound 4, half-maximal inhibitory concentration: 7.5 nM
Beside the measured number, compound 4's estimate is 1.1-fold (0.03 log units) above it; measured number inside the range.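

In this assay, putting 1-(cyclopropylsulfonyl)pyrrolidin-3-yl in place of pyrrolidin-3-yl gives a 40-fold lower number from compound 3 to compound 4 (1.60 log units; beyond the scatter), and this step matches the one seen without the fluoro group: the same change on two cores in this assay, a 41-fold lower number (1.61 log units; beyond the scatter) from compound 1 to compound 2 and a 40-fold lower number (1.60 log units; beyond the scatter) from compound 3 to compound 4, 1.0-fold (0.01 log units) apart, within the scatter of two such steps. Putting fluoro in place of hydrogen gives a 4.7-fold higher number from compound 2 to compound 4 (0.67 log units; beyond the scatter), so this change also carries over, whichever of the two groups sits on the aromatic nitrogen: the same change on two cores in this assay, a 4.6-fold higher number (0.66 log units; beyond the scatter) from compound 1 to compound 3 and a 4.7-fold higher number (0.67 log units; beyond the scatter) from compound 2 to compound 4, 1.0-fold (0.01 log units) apart, within the scatter of two such steps. The two changes therefore act independently across these four compounds, but this rests on a single set of four in one cell assay and does not show that other changes or other cores would behave alike.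

The compounds shown leave open whether a methylsulfonyl or acetyl group in place of cyclopropylsulfonyl would give a step of this size. They also leave open whether chloro or methoxy in place of fluoro would shift the number as fluoro does.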